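Swapping the amino-acid arm on a spiro urea core

The source may hold more compounds than are shown below. What is called first, only, known or untested is meant among the compounds shown, and "the series" means these compounds.

Of the compounds shown here, two have been tested in an assay on HEK293 cells for inhibition of Voltage-dependent T-type calcium channel subunit alpha-1H (Homo sapiens), read by patch clamp, using a membrane potential dye; on this read-out lower numbers stand for stronger inhibition and higher numbers for weaker inhibition. Compound 1 `CC[C@H](C)[C@H](NC(=O)N1CCC2(CC1)CN(C1CC1)C2c1ccc(Cl)cc1)C(=O)OC` gives 325 nM in this assay. Compound 2 `CC[C@H](C)[C@H](NC(=O)N1CCC2(CC1)C(=O)N(c1cccc(F)c1)C2c1ccc(Cl)cc1)C(=O)OC(C)C` gives 45 nM in this assay, the lowest of the two numbers; the two compounds differ in several places at once, so their values are simply shown side by side without a single step between them.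

Compound 3 `COC(=O)[C@H](COC(C)(C)C)NC(=O)N1CCC2(CC1)C(=O)N(c1cccc(F)c1)C2c1ccc(Cl)cc1` has not yet been measured. It keeps the whole core of compound 2 and changes only the arm attached through the urea: a group of 11 heavy atoms (8 carbon, 3 oxygen; no ring) in place of a group of 11 heavy atoms (9 carbon, 2 oxygen; no ring), on an amide-type nitrogen. The arm that enters is 1-(methoxycarbonyl)-2-(tert-butoxy)ethyl, which keeps the ester and carries one more oxygen than the arm it replaces.

For the measured compounds named here, no measured pair in this set isolates this kind of change, so the expectation rests on the closeness of the two arms. The step from compound 2 to compound 3 is expected to be small, a 1.8-fold higher number from compound 2 to compound 3 (0.25 log units; within the scatter), most likely a modest weakening that may not exceed the scatter. Compound 3 is therefore estimated to give 80 nM in this assay, within a range of 25 nM to 250 nM.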

Compound 3, half-maximal inhibitory concentration: 251 nM
Compound 3: middle estimate off by 3.1-fold (0.50 log units), on the low side, outside the stated range (above it).
By their numbers in this assay, from the lowest: compound 2; then compounds 3 and 1 (each within the scatter of the next).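

In this assay, changing only the arm on the amide-type nitrogen while the rest of compound 2 stays in place gives a 5.6-fold higher number from compound 2 to compound 3 (0.75 log units; beyond the scatter), so this position responds clearly to a change of arm. The two arms have the same heavy-atom count, and both lack a ring and keep an ester, so these shared features do not protect the value; the entering 1-(methoxycarbonyl)-2-(tert-butoxy)ethyl arm differs by holding one more oxygen and one fewer carbon, along with a different branching pattern. Nothing measured here explains why the number rises.

This one step changes the ester from isopropyl to methyl and also replaces the hydrocarbon side chain with a tert-butoxy-bearing one, so the compounds shown cannot tell which of these changes accounts for the step. From the compounds shown here alone, it also remains open how the value would respond to a carboxylic acid in place of the ester, or to a simple amine or a longer hydrocarbon chain on this arm.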